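The compounds below may be only part of what the source reports. "The series", "measured", "known", "first", "only" and "open" are said of these compounds alone.

In a functional assay on KB cells (Homo sapiens) for antiproliferative activity, read by MTT assay, with a stated time of 72 h (on this read-out lower numbers stand for stronger inhibition and higher numbers for weaker inhibition), three compounds sharing one core have been measured. Compound 1 (`CCOC(=O)c1cc(-c2cc(OC)c(OC)c(OC)c2)c(-c2ccc(OC)cc2)s1`) gives 13200 nM, compound 2 (`COc1ccc(-c2sc(C(=O)O)cc2-c2cc(OC)c(OC)c(OC)c2)cc1`) gives 10400 nM, and compound 3 (`COc1cc(-c2cc(C(=O)O)sc2-c2cccc(Br)c2)cc(OC)c1OC`) gives 32300 nM. Replacing ethyl with hydrogen on the oxygen next to the carbonyl group gives a 1.3-fold lower number from compound 1 to compound 2 (0.10 log units; within the scatter), and replacing 4-methoxyphenyl with 3-bromophenyl gives a 3.1-fold higher number from compound 2 to compound 3 (0.49 log units; beyond the scatter). Compound 2 therefore stands level with compound 1 and under compound 3.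

Compound 4 (`COc1ccc(-c2sccc2-c2cc(OC)c(OC)c(OC)c2)cc1`) has hydrogen in place of carboxy on an aromatic carbon, next to the ring sulfur: hydrogen in place of carboxy on an aromatic carbon. For the measured compounds named here, no measured step removes this group. The closest evidence, a 1.3-fold lower number from compound 1 to compound 2 (0.10 log units; within the scatter), alters the group without removing it, and the modest step to compound 3 lies elsewhere on the core. All three measured compounds carry the carbonyl and all read high, so a lower number is tentatively expected, with a size the data cannot fix. The expected change is a 6.9-fold lower number from compound 2 to compound 4 (0.84 log units; beyond the scatter), larger than either measured step but uncertain. For compound 4 the estimate is 1500 nM, with an expected range from 60 nM to 15000 nM.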

Compound 4, half-maximal inhibitory concentration: 8880 nM
Estimate against measurement, compound 4: 5.9-fold (0.77 log units) below, within the range that was stated.
By their numbers in this assay, from the lowest: compounds 4, 2 and 1 (each within the scatter of the next); then compound 3.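

In this assay, the aromatic carbon next to the ring sulfur now has a direct test, since removing carboxy gives a 1.2-fold lower number from compound 2 to compound 4 (0.07 log units; within the scatter) and removing ethoxycarbonyl gives a 1.5-fold lower number from compound 1 to compound 4 (0.17 log units; within the scatter), so both steps stay within the scatter. The earlier compounds shown here all kept the carbonyl group here and showed only that exchanging ethyl for hydrogen on it left the number level; compound 4 shows that the number also stays level with compounds 1 and 2 when the whole group is gone, so the high numbers of those two do not depend on that group. No separate data explain why this position shows so little change.

Going by these compounds, whether an amine or an amide on this carbon would read differently remains open. Also open, on these data alone, is whether the 3-bromophenyl in place of 4-methoxyphenyl change, seen so far only with carboxy present, would give a similar step on the core of compound 4.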